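Moving the trifluoromethoxy group in a flat series

The compounds below may be only part of what the source reports. "The series", "measured", "known", "first", "only" and "open" are said of these compounds alone.

In a functional assay on DU-145 cells (Homo sapiens) for antiproliferative activity, read by propidium iodide staining, with a stated time of 96 h (a higher number here means a weaker inhibitor, a lower number a stronger inhibitor), compound 1 `CC(O)(CS(=O)(=O)c1ccc(C(F)(F)F)cc1)C(=O)Nc1ccc(S(F)(F)(F)(F)F)cc1` gives 29300 nM, compound 2 `CC(O)(CS(=O)(=O)c1cccc(C(F)(F)F)c1)C(=O)Nc1ccc(S(F)(F)(F)(F)F)cc1` gives 31900 nM and compound 3 `CC(O)(CS(=O)(=O)c1cccc(OC(F)(F)F)c1)C(=O)Nc1ccc(S(F)(F)(F)(F)F)cc1` gives 26500 nM. Compound 3 stands level with the other two, as all steps among them lie within the scatter. Compound 4 `CC(O)(CS(=O)(=O)c1ccccc1OC(F)(F)F)C(=O)Nc1ccc(S(F)(F)(F)(F)F)cc1` differs from compound 3 in one change: 2-(trifluoromethoxy)phenyl in place of 3-(trifluoromethoxy)phenyl on a sulfonyl sulfur. Going by the values given here, the closest precedent is a 1.1-fold higher number from compound 1 to compound 2 (0.04 log units; within the scatter), where 3-(trifluoromethyl)phenyl replaces 4-(trifluoromethyl)phenyl. The other steps, a 1.1-fold lower number from compound 1 to compound 3 (0.04 log units; within the scatter) and a 1.2-fold lower number from compound 2 to compound 3 (0.08 log units; within the scatter), are also small. None of them tests a 2-(trifluoromethoxy)phenyl group, so the forecast is uncertain, but no step beyond the scatter is expected in this assay. The expected step is a 1.1-fold higher number from compound 3 to compound 4 (0.02 log units; within the scatter). For compound 4 the estimated value is 28000 nM, with an expected range of 15000 nM to 50000 nM.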

Compound 4, half-maximal inhibitory concentration: 19500 nM
The estimate for compound 4 lay 1.4-fold (0.16 log units) above the measured number, and the stated range covers the measured number.
By their numbers in this assay, from the lowest: compounds 4, 3, 1 and 2 (each within the scatter of the next).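

In this assay, 2-(trifluoromethoxy)phenyl on the sulfonyl sulfur can stand in for 3-(trifluoromethoxy)phenyl with no real change (a 1.4-fold lower number from compound 3 to compound 4 (0.13 log units; within the scatter)). The same holds against the two trifluoromethyl compounds (a 1.6-fold lower number from compound 2 to compound 4 (0.21 log units; within the scatter); a 1.5-fold lower number from compound 1 to compound 4 (0.18 log units; within the scatter)), so all four compounds stand level and the series stays flat with this new arrangement on the ring. Nothing measured here bears on the reason for this flatness.

Still open, as far as these compounds go, is whether an amine or a carboxylic acid on the ring would leave this flat range. From the compounds shown here alone, what changes elsewhere in the shared core would do also remains open.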